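The source may hold more compounds than are shown below. What is called first, only, known or untested is meant among the compounds shown, and "the series" means these compounds.

Among the measured compounds shown here, compound 1 `COc1ccc2[nH]c3c(c2c1)CCNC31CCN(Cc2c(F)ccc(Cl)c2F)CC1` gives 1500 nM in an assay on FRT cells for positive allosteric modulation of Cystic fibrosis transmembrane conductance regulator variant N1303K (Homo sapiens), in the presence of a further agent that is not named here (on this read-out lower numbers stand for an effect already at smaller amounts and higher numbers for an effect only at larger amounts of compound), the lowest of the three numbers measured so far. Compound 2 `COc1ccc2[nH]c3c(c2c1)CCNC31CCN(Cc2ccc(Br)cc2F)CC1` gives 1600 nM, and the step of a 1.1-fold higher number from compound 1 to compound 2 (0.03 log units; within the scatter) lies within the scatter, so these two compounds cannot be told apart. Compound 3 `COc1ccc2[nH]c3c(c2c1)CCNC31CCN(Cc2cc(F)ccc2F)CC1` gives 11100 nM, and here the step of a 7.4-fold higher number from compound 1 to compound 3 (0.87 log units; beyond the scatter) is clear; the matching step a 6.9-fold higher number from compound 2 to compound 3 (0.84 log units; beyond the scatter) points the same way. Compound 4 `COc1ccc2[nH]c3c(c2c1)CCNC31CCN(Cc2ccc(F)c(F)c2)CC1` is not yet measured. It differs from compound 1 in one place: 3,4-difluorophenyl in place of 3-chloro-2,6-difluorophenyl on a saturated chain carbon bound to an amine nitrogen in a ring. For the measured compounds named here, the step that bears most on this change is the one to compound 3, whose 2,5-difluorophenyl is nearest in kind to the 3,4-difluorophenyl of compound 4, and that step raised the number modestly, while the exchange between the groups of compound 1 and compound 2 changed nothing beyond the scatter. A higher number than for compound 1 is therefore expected, modest rather than large. Compound 4 is estimated at 5000 nM, in a range from 1500 nM to 16000 nM. This estimate corresponds to an expected step of a 3.3-fold higher number from compound 1 to compound 4 (0.52 log units; beyond the scatter).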

Compound 4, half-maximal effective concentration: 11000 nM
Estimate against measurement, compound 4: 2.2-fold (0.34 log units) below; the measured number falls inside the stated range.
By their numbers in this assay, from the lowest: compounds 1 and 2 (each within the scatter of the next); then compounds 4 and 3 (each within the scatter of the next).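

The step of a 1.0-fold lower number from compound 3 to compound 4 (0.00 log units; within the scatter) means that the 3,4-difluorophenyl and 2,5-difluorophenyl groups cannot be told apart in this assay, even though their fluorines sit at different places on the ring. The steps of a 7.3-fold higher number from compound 1 to compound 4 (0.87 log units; beyond the scatter) and a 6.9-fold higher number from compound 2 to compound 4 (0.84 log units; beyond the scatter) place compound 4 clearly apart from the halogen-bearing pair, so among these four compounds the two groups carrying chlorine or bromine give lower numbers than the two carrying only fluorine, and no compound goes against this. No measured evidence here explains this split.

Still open, on these data alone, is whether the chlorine or bromine atom itself goes with the lower numbers. A methyl, methoxy or trifluoromethyl group on the same ring might do equally well, and a plain phenyl would give the baseline.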